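A few compounds are considered here, and "the series" means these few. Any claim that something is new, unique, unknown or untested is made for them only; others in the source may bear on it.

Compound 3 `COC(=O)C1=C(C)N=C(C)/C(=C(\O)OC)C1c1cccc(Cl)c1Cl` gives the lowest number of the three measured in a functional assay (muscle tissue) with Cavia porcellus as the target (a higher number here means that more compound is needed for the effect, a lower number that less compound is needed), at 19.1 nM. Compound 1 `COC(=O)C1=C(C)N=C(C)/C(=C(\O)OC)C1c1cccc(OC(C)=O)c1` gives 6030 nM and compound 2 `COC(=O)C1=C(C)N=C(C)/C(=C(\O)OC)C1c1cccc(OC(=O)c2ccccc2)c1` gives 6310 nM in this assay, the two far above compound 3. Within the data shown here, the only measured step, a 1.0-fold higher number from compound 1 to compound 2 (0.02 log units; within the scatter), changes a distant acyl group and says little about the aryl ring itself. Compound 4 `COC(=O)C1=C(C)N=C(C)/C(=C(\O)OC)C1c1ccc(F)cc1` differs from compound 3 in that ring: 4-fluorophenyl in place of 2,3-dichlorophenyl on a saturated ring carbon. Among the measured compounds shown here, no measured pair tests this change, but compounds 1 and 2 show that an aryl group unlike 2,3-dichlorophenyl can give a much higher number. Compound 4 is therefore expected to show a large loss, a 100-fold higher number from compound 3 to compound 4 (2.02 log units; beyond the scatter), with an estimated 2000 nM and a range from 300 nM to 15000 nM.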

Compound 4, half-maximal effective concentration: 129 nM
Compound 4: middle estimate off by 16-fold (1.19 log units), on the high side; measured number below the stated range.
By their numbers in this assay, from the lowest: compound 3; then compound 4; then compounds 1 and 2 (each within the scatter of the next).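

In this assay, among these compounds, 4-fluorophenyl in place of 2,3-dichlorophenyl on a saturated ring carbon gives a 6.8-fold higher number from compound 3 to compound 4 (0.83 log units; beyond the scatter), a first direct reading of a change to the halogens on this aryl ring. The printed values put compound 4 well under compounds 1 and 2, so the two chlorines are not required for a low number here. Nothing available explains the size of this step. The change alters the halogen, its count and its ring position together, leaving open which of these matters. From the compounds shown here alone, what 4-chlorophenyl or an aryl ring carrying an amine would give also remains open.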